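Hydroxycycloalkyl exchange on the amide nitrogen

A few compounds are considered here, and "the series" means these few. Any claim that something is new, unique, unknown or untested is made for them only; others in the source may bear on it.

Values in a physicochemical assay for solubility, at pH 6.8; on this read-out higher numbers stand for higher solubility and lower numbers for lower solubility:
- compound 1 `CCN(CC)C1CCN(Cc2ccc(-c3cnc(N)c(C(=O)N[C@H]4CC[C@H](O)CC4)n3)cc2)CC1`: > 1000000 nM (a limit of the assay, not a number)
- compound 2 `CN(C)Cc1ccc(-c2cnc(N)c(C(=O)NC3CCCC3O)n2)cc1`: 940000 nM

For the measured compounds named here, compound 2 stands at 940000 nM as the only true number so far. Compound 3 `CN(C)Cc1ccc(-c2cnc(N)c(C(=O)NC3CCC(O)CC3)n2)cc1` carries 4-hydroxycyclohexyl in place of 2-hydroxycyclopentyl on an amide-type nitrogen. Going by the values given here, no measured step bears on this exchange. Compound 1 also carries 4-hydroxycyclohexyl and gives > 1000000 nM as a limit. The expected step of a 1.1-fold lower number from compound 2 to compound 3 (0.04 log units; within the scatter) in this assay is estimated to stay within the usual scatter, in neither direction. Compound 3 is expected at 850000 nM (estimated range 350000 nM to 1000000 nM) in this read-out.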

Compound 3, solubility: 850000 nM
Compound 3: middle estimate and measured number agree at the digits printed; measured number inside the range.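

At this position, on an amide-type nitrogen, 4-hydroxycyclohexyl in place of 2-hydroxycyclopentyl gives in this assay a 1.1-fold lower number from compound 2 to compound 3 (0.04 log units; within the scatter). The two hydroxycycloalkyl groups therefore cannot be told apart in this read-out. Any reading of the series must also allow for a limit of the read-out: the limit of > 1000000 nM in this assay, at which 1 of the 3 values shown sits.

Still open, from the compounds shown here alone, is whether an open-chain hydroxyalkyl group on this nitrogen, or an amine or a carboxylic acid in place of the hydroxyl on the ring, would give a step beyond the scatter.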